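Swapping acetoxy for chloro on two pyrimidine cores

A few compounds are considered here, and "the series" means these few. Any claim that something is new, unique, unknown or untested is made for them only; others in the source may bear on it.

Measured so far in a functional assay on MCF7 cells (Homo sapiens) for antiproliferative activity, read by MTT assay, with a stated time of 24 h; a higher number here means a weaker inhibitor, a lower number a stronger inhibitor:
- compound 1 `CC(=O)OCCc1c(C)[nH]c(=O)[nH]c1=O`: compound 1 reaches only the limit > 100000 nM
- compound 2 `COc1nc(C)c(CCOC(C)=O)c(OC)n1`: compound 2 gives 65000 nM
- compound 3 `Cc1[nH]c(=O)[nH]c(=O)c1CCCl`: compound 3 reaches only the limit > 100000 nM

Compound 1 and compound 3 share a core, and compound 3 differs from compound 1 by one change, (chloro in place of acetoxy on a saturated chain carbon, two bonds along the chain from an aromatic carbon). Both of these compounds return only a limit of the assay, so the step that the two limits leave unreadable from compound 1 to compound 3 cannot be read in size because of the limit of > 100000 nM in this assay, at which 2 of the 3 values shown sit.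

Compound 2 carries a different core; how the core of compound 2 differs from the core of compound 1 is not broken down here. Compound 2 is the only one of the three to give an actual number in this assay.

The unmeasured compound 4 `COc1nc(C)c(CCCl)c(OC)n1` stands to compound 2 as compound 3 stands to compound 1: the change is chloro in place of acetoxy on a saturated chain carbon, two bonds along the chain from an aromatic carbon, made at the same place as before. For the measured compounds named here, on the first core the step was left unreadable, so the only anchor is the value of compound 2. Going by the values given here, the step of a 1.1-fold higher number from compound 2 to compound 4 (0.03 log units; within the scatter) is expected to stay small, since the one measured instance of this change gave no sign of a large shift. Compound 4 is therefore estimated at 70000 nM, with a likely range from 25000 nM to 200000 nM in this assay, and a fair chance that it, too, returns only a limit.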

Compound 4, half-maximal inhibitory concentration: > 100000 nM
Compound 4 ended at the assay's limit (the forecaster's own chance of this, stated with the estimate: 35%); middle value at least 1.4-fold (0.15 log units) away from the limit.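

Compound 4 gives > 100000 nM in this assay, and this is a limit of the assay and not a number. For the compounds shown here, on the core of compound 2, chloro in place of acetoxy therefore gives only a floor for the step, an at least 1.5-fold higher number from compound 2 to compound 4 (0.18 log units; that floor lies within the scatter), so the acetoxy compound keeps the only actual number in the set, while the true size of the step could be small or much larger. This does not show that the change has the same effect on both cores, since the step on the core of compound 1 cannot be read at all and the step on the second core has no upper end, so the two cannot be set side by side, and there is one reason for both gaps: the limit of > 100000 nM in this assay, at which 3 of the 4 values shown sit.

The compounds shown leave open what an amine or a carboxylic acid would do in place of the acetoxy on this chain, and whether a longer chain carrying the acetoxy or the chloro would give a readable number on either core. They also leave open how far above the limit compound 4 and the two compounds on the other core really lie.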